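From 2-chlorophenyl to 4-methylphenyl on the shared core

The source may report more compounds than this note shows. Statements on the series, on what has been measured and on what is new or still open speak of the compounds shown alone.

Among the measured compounds shown here, in a functional assay on U-87MG ATCC cells for inhibition, with U-87 MG (Homo sapiens) as the target, read by MTT assay, with a stated time of 72 h (on this read-out lower numbers stand for stronger inhibition and higher numbers for weaker inhibition), only two compounds have numbers so far. Compound 1 `Oc1c(C(Nc2ccccn2)c2ccccc2Cl)ccc2cccnc12` gives 9400 nM, the higher of the two, while compound 2 `Oc1ccc2scnc2c1C(c1ccc(F)cc1)N1CCCCC1` gives 1000 nM, a lower number by a margin beyond the scatter. For the measured compounds named here, these two compounds differ in more than one place, so they offer no measured step for a single change.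

Compound 3 `Cc1ccc(C(Nc2ccccn2)c2ccc3cccnc3c2O)cc1` keeps the core of compound 1 and changes one group: 4-methylphenyl in place of 2-chlorophenyl on a saturated chain carbon bound to an aromatic carbon and a nitrogen on an aromatic ring. Going by the values given here, no measured pair in this assay shows a swap of this kind. The expectation is therefore a small move towards a lower number, with no step beyond the scatter. The expected step is a 1.3-fold lower number from compound 1 to compound 3 (0.13 log units; within the scatter). Compound 3 is estimated at 7000 nM, with an expected range of 2500 nM to 20000 nM.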

Compound 3, half-maximal inhibitory concentration: > 10000 nM
Compound 3: a limit, no number; the forecaster's own chance of this, stated with the estimate: 10%; middle value at least 1.4-fold (0.15 log units) from the limit.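

Compound 3 carries a limit of the assay in this assay, not a number: > 10000 nM. The swap to 4-methylphenyl from 2-chlorophenyl on a saturated chain carbon bound to an aromatic carbon and a nitrogen on an aromatic ring now has a first measured step, an at least 1.0-fold higher number from compound 1 to compound 3 (0.02 log units; that floor lies within the scatter), so the move towards a lower number does not appear at this position. The true size of the step cannot be read, because the value sits at the limit: the limit of > 10000 nM in this assay, at which 1 of the 3 values shown sits.

The compounds shown leave open whether the loss of chlorine or the shift in where the ring carries its group governs this result, which a 4-chlorophenyl or a plain phenyl in the same place could separate. Also open, going by these compounds, is how an amine or a carboxylic acid on this ring would read.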